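A Methoxy Removed From a Weak Inhibitor

The compounds below may be only part of what the source reports. "The series", "measured", "known", "first", "only" and "open" are said of these compounds alone.

Compound 1, `COc1ccc(/C=C/C=C/C(=O)c2ccc[nH]2)cc1`, was examined in an assay for inhibition of cytochrome P450 1A1 (Homo sapiens), read by fluorescence, using microsomes, with a stated time of 10 min; a higher number here means a weaker inhibitor, a lower number a stronger inhibitor. In this assay compound 1 gives > 20000 nM, which is a limit of the assay and not a number. Going by the values given here, the only other measured compound is compound 2, `O=C(/C=C/c1cccc(Cl)c1)c1ccc[nH]1`; in this assay compound 2 gives 16000 nM. From the compounds shown here alone, compound 1 therefore stands at the edge of what the measurement can report, namely (the limit of > 20000 nM in this assay, at which 1 of the 2 values shown sits), so its true value is unknown beyond that edge.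

Compound 3, `O=C(/C=C/C=C/c1ccccc1)c1ccc[nH]1`, differs from compound 1 by hydrogen in place of methoxy on an aromatic carbon. Among the compounds with values here, no pair of measured compounds differing in a single place is available to calibrate such a change, so no direction can be claimed; the step is expected to stay within the scatter, most likely leaving compound 3 at the limit as well. Compound 3 is estimated at 20000 nM, with a range from 8000 nM to 50000 nM. That estimate corresponds to an expected step of a number no higher from compound 1 to compound 3 (the limit leaves the size open), which is not expected to exceed the scatter.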

Compound 3, half-maximal inhibitory concentration: > 20000 nM
Compound 3 was reported as a limit (the forecaster's own chance of this, stated with the estimate: 60%); the middle value sits exactly at the limit.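

Compound 1 and compound 3 both stand at a limit in this assay, so no step can be read between them: the limit of > 20000 nM in this assay, at which 2 of the 3 values shown sit.

The compounds shown leave open how much true inhibition either compound has, and whether exchanging methoxy for hydrogen changes it at all.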